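Compound 3 and the step to compound 4

The source may hold more compounds than are shown below. What is called first, only, known or untested is meant among the compounds shown, and "the series" means these compounds.

Compound 1 `CC(Nc1nc(N)nc2ccc(-c3cnn(C4CCNCC4)c3)cc12)c1c(Cl)ccc(F)c1Cl`: 8800 nM in a functional assay on A549 cells (Homo sapiens) for antiproliferative activity, read by MTT assay, with a stated time of 72 h; a lower number here means a stronger inhibitor, a higher number a weaker inhibitor
Compound 2 `CC(Oc1nc(N)nc2ccc(-c3cnn(C4CCNCC4)c3)cc12)c1c(Cl)ccc(F)c1Cl`: 9490 nM in this assay
Compound 3 `Cn1cc(-c2ccc3ncnc(Nc4ccc(F)c(Cl)c4)c3c2)cn1`: > 100000 nM in this assay

Compound 3 gives no number in this assay, only a limit, (the limit of > 100000 nM in this assay, at which 1 of the 3 values shown sits). Compound 1 and compound 2 do give numbers, and both sit close together. Compound 4 `C#Cc1cccc(Nc2ncnc3ccc(-c4cnn(C)c4)cc23)c1` differs from compound 3 by 3-ethynylphenyl in place of 3-chloro-4-fluorophenyl on a nitrogen on an aromatic ring. For the measured compounds named here, no step between two measured compounds is known here, so the size of this change cannot be read from the data. Compound 4 is therefore expected to show a step of a number no higher from compound 3 to compound 4 (the limit leaves the size open) of no clear size in either direction, and most likely none beyond the scatter. The estimate for compound 4 is 100000 nM, with a range from 20000 nM to 500000 nM, and a further limit rather than a number is the more likely outcome.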

Compound 4, half-maximal inhibitory concentration: 9860 nM
Beside the measured number, compound 4's estimate is 10-fold (1.01 log units) above it; measured number outside the range, below it.
By their numbers in this assay, from the lowest: compounds 1, 2 and 4 (each within the scatter of the next). At a limit, above all of these: compound 3.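

In this assay, for the compounds shown here, 3-ethynylphenyl in place of 3-chloro-4-fluorophenyl on a nitrogen on an aromatic ring gives an at least 10-fold lower number from compound 3 to compound 4 (1.00 log units; beyond the scatter), so the number at this position does respond to the group placed there, which the earlier compounds could not show. Compound 3 stands only at a limit, so the full size of this step stays open: the limit of > 100000 nM in this assay, at which 1 of the 4 values shown sits.

The compounds shown do not separate the gain of the ethynyl group from the loss of chlorine and fluorine. From the compounds shown here alone, whether a plain phenyl, or a phenyl carrying an amine or a carboxylic acid, would keep the lower number also remains open.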